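The source may report more compounds than this note shows. Statements on the series, on what has been measured and on what is new or still open speak of the compounds shown alone.

Measured so far:
compound 1, `COc1ccc(OCC(=O)N2CCN(c3ccc(C(F)(F)F)cc3[C@@H](N)CC(C)C)CC2)cc1`: 3800 nM
compound 2, `CC(C)C[C@H](N)c1cc(C(F)(F)F)ccc1N1CCN(C(=O)CCC(N)=O)CC1`: > 10000 nM

Compound 2 sits at the limit of > 10000 nM in this assay, at which 1 of the 2 values shown sits; in an assay on HEK293 cells for displacement of a labelled ligand from Melanocortin receptor 4 (Homo sapiens) (a higher number here means a weaker inhibitor, a lower number a stronger inhibitor), compound 2 reports only a limit of the assay, not a number. Compound 1, by contrast, gives 3800 nM in this assay. For the measured compounds named here, the one measured step, an at least 2.6-fold higher number from compound 1 to compound 2 (0.42 log units; beyond the scatter), is the only comparison available and it shows that removing the aromatic ring from the group on the carbonyl carbon weakened binding at least modestly.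

Compound 3, `CC(C)C[C@H](N)c1cc(C(F)(F)F)ccc1N1CCN(C(=O)[C@H](C)Cc2ccc(Cl)cc2)CC1`, differs from compound 2 by 1-(4-chlorobenzyl)ethyl in place of 2-carbamoylethyl on a carbonyl carbon. This change runs opposite to the measured step: an aromatic ring re-enters on the carbonyl carbon, where compound 1 with its aromatic ring was measurable and compound 2 without one was not. On that basis compound 3 is expected to move back toward or past compound 1, an expected step of an at least 6.6-fold lower number from compound 2 to compound 3 (0.82 log units; beyond the scatter). Compound 3 is estimated at 1500 nM, within 300 nM to 8000 nM.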

Compound 3, inhibition constant: 31 nM
Compound 3: middle estimate off by 48-fold (1.68 log units), on the high side; the measured number lies below the stated range.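

In this assay, an aromatic ring on this carbonyl carbon does not by itself fix the level. Compound 1 and compound 3 both carry one, yet 1-(4-chlorobenzyl)ethyl in place of (4-methoxyphenoxy)methyl gives a 120-fold lower number from compound 1 to compound 3 (2.09 log units; beyond the scatter). With 2-carbamoylethyl as the group replaced, the change gives an at least 320-fold lower number from compound 2 to compound 3 (2.50 log units; beyond the scatter), and compound 2 reports only a limit, not a number: the limit of > 10000 nM in this assay, at which 1 of the 3 values shown sits.

The compounds shown leave open which part of 1-(4-chlorobenzyl)ethyl carries these steps: the chlorine, the defined stereocentre or the chain to the ring. Also open, going by these compounds, is whether a fluorine or a nitrile in place of the chlorine, or a longer chain, would keep compound 3's level on this carbonyl carbon.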